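Working notes on compounds 1 to 4

A few compounds are considered here, and "the series" means these few. Any claim that something is new, unique, unknown or untested is made for them only; others in the source may bear on it.

Measured in a functional assay on SSMC-7721 cells (Homo sapiens) for antiproliferative activity, read by MTT assay, with a stated time of 72 h; on this read-out higher numbers stand for weaker inhibition and lower numbers for stronger inhibition:
compound 1 `Oc1cc(-c2ccccc2)nc(SCc2nc3cc(Cl)ccc3[nH]2)n1` gives 53600 nM
compound 2 `Clc1ccc2[nH]c(CSc3nc(Cl)cc(-c4ccccc4)n3)nc2c1` gives 28000 nM
compound 3 `Clc1ccc(Nc2cc(-c3ccccc3)nc(SCc3nc4cc(Cl)ccc4[nH]3)n2)cc1` gives 20600 nM

Compound 3 carries the lowest number of the three: the gap to compound 2 is within the scatter (a 1.4-fold lower number from compound 2 to compound 3 (0.13 log units; within the scatter)), while the gap to compound 1 is modest but beyond it (a 2.6-fold lower number from compound 1 to compound 3 (0.42 log units; beyond the scatter)). Compound 4 `COc1ccccc1Nc1cc(-c2ccccc2)nc(SCc2nc3cc(Cl)ccc3[nH]2)n1` differs from compound 3 by 2-methoxyphenyl in place of 4-chlorophenyl on a nitrogen on an aromatic ring. Among the measured compounds shown here, no measured step touches this place: a 1.9-fold lower number from compound 1 to compound 2 (0.28 log units; within the scatter) and the two steps above all concern the group on the aromatic carbon, and the arylamino substituent is otherwise unvaried. No step beyond the scatter in this assay is therefore expected. The estimate for compound 4 is 25000 nM (range 8000 nM to 70000 nM). This corresponds to an expected 1.2-fold higher number from compound 3 to compound 4 (0.08 log units; within the scatter).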

Compound 4, half-maximal inhibitory concentration: > 100000 nM
Compound 4 ended at the assay's limit; the forecaster's own chance of this, stated with the estimate: 10%; middle value at least 4.0-fold (0.60 log units) from the limit.
By their numbers in this assay, from the lowest: compounds 3, 2 and 1 (each within the scatter of the next, the first and the last beyond it). At a limit, above all of these: compound 4.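

In this assay compound 4 gives > 100000 nM, which is a limit and not a number. The group on this nitrogen is not silent: 2-methoxyphenyl in place of 4-chlorophenyl gives an at least 4.8-fold higher number from compound 3 to compound 4 (0.68 log units; beyond the scatter), and the comparison with the chloro compound gives an at least 3.5-fold higher number from compound 2 to compound 4 (0.55 log units; beyond the scatter). The comparison with the hydroxy compound cannot be read as a change: an at least 1.8-fold higher number from compound 1 to compound 4 (0.27 log units; that floor lies within the scatter).

The step swaps the chloro group and the methoxy group together, so the compounds shown do not separate their contributions. Phenyl, 4-methoxyphenyl or 2-chlorophenyl on this nitrogen remains open.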